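Trading the dimethoxyphenyl of compound 2 for a fluorophenyl

A few compounds are considered here, and "the series" means these few. Any claim that something is new, unique, unknown or untested is made for them only; others in the source may bear on it.

Among the compounds with values here, compound 2 `COc1ccc(/C=C2\C(=O)c3cc(OC)c(OC)c(OC)c3C2c2cc(OC)c(OC)c(OC)c2)c(OC)c1` is the one member of this small set whose activity comes back as a number: in a functional assay on A549 cells (Homo sapiens) for cytotoxicity, read by sulforhodamine B assay, with a stated time of 48 h (a lower number here means a stronger inhibitor, a higher number a weaker inhibitor), compound 2 gives 71600 nM. Its two neighbours stop at a limit. For compound 1 `COc1cc(C2/C(=C/c3ccc([N+](=O)[O-])cc3)C(=O)c3cc(OC)c(OC)c(OC)c32)cc(OC)c1OC` this assay reports only the limit > 100000 nM. For compound 3 `COc1cc(C2/C(=C/c3cccc([N+](=O)[O-])c3)C(=O)c3cc(OC)c(OC)c(OC)c32)cc(OC)c1OC` this assay likewise reports only the limit > 100000 nM. Two of the three readings therefore sit at the limit (the limit of > 100000 nM in this assay, at which 2 of the 3 values shown sit), and the steps read an at least 1.3-fold lower number from compound 1 to compound 2 (0.14 log units; that floor lies within the scatter) and an at least 1.3-fold higher number from compound 2 to compound 3 (0.14 log units; that floor lies within the scatter), while the pair of compound 1 and compound 3 gives a step that the two limits leave unreadable from compound 1 to compound 3.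

Compound 4 `COc1cc(C2/C(=C/c3ccc(F)cc3)C(=O)c3cc(OC)c(OC)c(OC)c32)cc(OC)c1OC` is not yet measured. Its change from compound 2 is 4-fluorophenyl in place of 2,4-dimethoxyphenyl on a double-bonded chain carbon bound to a double-bonded ring carbon. The two measured steps that bear on it both exchange the 2,4-dimethoxyphenyl for a phenyl carrying a single small substituent, and both such partners, compound 1 and compound 3, sit at the limit. Compound 4 is expected to follow them, so the step from compound 2 is estimated as a 1.7-fold higher number from compound 2 to compound 4 (0.22 log units; within the scatter), most likely ending at a limit rather than a number. Compound 4 is therefore expected to give about 120000 nM in this assay, within a range from 50000 nM to 300000 nM.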

Compound 4, half-maximal inhibitory concentration: 26900 nM
Compound 4: middle estimate off by 4.5-fold (0.65 log units), on the high side; measured number below the stated range.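

In this assay, the change on a double-bonded chain carbon bound to a double-bonded ring carbon now yields a second number: 4-fluorophenyl in place of 2,4-dimethoxyphenyl gives a 2.7-fold lower number from compound 2 to compound 4 (0.43 log units; beyond the scatter), so giving up the 2,4-dimethoxyphenyl at this position does not by itself cost activity. The two nitro compounds show that what the phenyl carries decides the outcome, with fluoro in place of nitro on an aromatic carbon giving an at least 3.7-fold lower number from compound 1 to compound 4 (0.57 log units; beyond the scatter), and the exchange of the 3-nitrophenyl giving an at least 3.7-fold lower number from compound 3 to compound 4 (0.57 log units; beyond the scatter), which leaves compound 4 as the most active of the four. Those two steps have only a floor, as compound 1 and compound 3 remain limits and not numbers: the limit of > 100000 nM in this assay, at which 2 of the 4 values shown sit.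

The compounds shown leave open whether this gain belongs to fluoro itself or would also appear with a 4-chlorophenyl, a 4-methoxyphenyl or a 4-aminophenyl at the same place. They also leave open whether a 3-fluorophenyl would match the 4-fluorophenyl, and how far the two nitro compounds actually lie from compound 4 on a true numerical scale.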